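From methoxy to nitro at the assay limit

This account rests on a few compounds, and the source may have more. Where it says the series, first, only, none or still open, it means among the compounds named here.

In a functional assay on A549 cells (Homo sapiens) for cytotoxicity, read by MTT assay, with a stated time of 4 days (a higher number here means a weaker inhibitor, a lower number a stronger inhibitor), compound 1 `COc1cc(C[C@H]2C(=O)OC[C@@H]2Cc2ccc(OC)c(OC)c2)ccc1NC(C)=O` gives > 50000 nM, which is a limit. Compound 2 `COc1ccc(Nc2ccc(C[C@H]3C(=O)OC[C@@H]3Cc3ccc(OC)c(OC)c3)cc2OC)cc1` gives > 50000 nM, also a limit. Between them lies a step that the two limits leave unreadable from compound 1 to compound 2. Compound 2 therefore stands at the limit of > 50000 nM in this assay, at which 2 of the 2 values shown sit. Compound 3 `COc1cc(C[C@H]2C(=O)OC[C@@H]2Cc2ccc(OC)c(OC)c2)ccc1Nc1ccc([N+](=O)[O-])cc1` has nitro in place of methoxy on an aromatic carbon, para to a large group: nitro in place of methoxy on an aromatic carbon. Going by the values given here, no measured step gives a size for this change, so little movement is expected, with any readable shift towards stronger inhibition. The expected change is a number no higher from compound 2 to compound 3 (the limit leaves the size open). The estimate for compound 3 is 50000 nM, with an expected range of 15000 nM to 100000 nM.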

Compound 3, half-maximal inhibitory concentration: 22100 nM
Compound 3: middle estimate off by 2.3-fold (0.35 log units), on the high side, within the range that was stated.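

In this assay, nitro in place of methoxy on an aromatic carbon, para to a large group, gives the first readable movement at this position: an at least 2.2-fold lower number from compound 2 to compound 3 (0.35 log units; beyond the scatter). 4-Nitrophenyl in place of acetyl on the nitrogen gives an at least 2.2-fold lower number from compound 1 to compound 3 (0.35 log units; beyond the scatter). Compound 1 and compound 2 stay at a limit: the limit of > 50000 nM in this assay, at which 2 of the 3 values shown sit.

The compounds shown leave open whether a nitrile or a carboxylic acid in this place would give a lower number than nitro. Going by these compounds, both steps start from a limit, and their true size stays open.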